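The source may hold more compounds than are shown below. What is called first, only, known or untested is meant among the compounds shown, and "the series" means these compounds.

Compound 1, `COc1ccc2nc(Nc3ccnc(Nc4ccc(S(N)(=O)=O)cc4)n3)sc2c1`: 11000 nM
Compound 2, `Cc1cnc(Nc2ccc(Cl)cc2)nc1Nc1nc2ccccc2s1`: > 50000 nM
Compound 3, `Cc1ccc2nc(Nc3ccnc(Nc4ccc(S(C)(=O)=O)cc4)n3)sc2c1`: > 50000 nM

Of the compounds shown here, three built on a shared core have been tested in a functional assay on MCF7 cells (Homo sapiens) for antiproliferative activity, read by MTT assay, with a stated time of 48 h; on this read-out higher numbers stand for weaker inhibition and lower numbers for stronger inhibition. Compound 1 is the only one of them to return a number, giving 11000 nM. For compound 2 the assay records only a limit, > 50000 nM. For compound 3 the result is likewise a limit, > 50000 nM. The set is thus shaped by the limit of > 50000 nM in this assay, at which 2 of the 3 values shown sit, which leaves compound 1 as the sole numerical anchor.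

The unmeasured compound 4, `NS(=O)(=O)c1ccc(Nc2nccc(Nc3nc4ccc(F)cc4s3)n2)cc1`, differs from compound 1 in one place: fluoro in place of methoxy on an aromatic carbon. Going by the values given here, no pair of measured compounds separated by a single change is available to gauge how much such a swap moves the read-out. The expectation in this assay is for no shift beyond the usual scatter of repeated measurements, in either direction.

Compound 4 is accordingly estimated at 12000 nM, within a range of 4000 nM to 40000 nM. The expected step is a 1.1-fold higher number from compound 1 to compound 4 (0.04 log units; within the scatter), which stays within the scatter.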

Compound 4, half-maximal inhibitory concentration: 10900 nM
Compound 4: the middle estimate sits 1.1-fold (0.04 log units) above what was measured; low and high end bracket the measured number.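

Fluoro in place of methoxy on an aromatic carbon gives, in this assay, a 1.0-fold lower number from compound 1 to compound 4 (0.00 log units; within the scatter), the first step between measured compounds that differ in one place. At this position, on a six-membered aromatic ring of carbon only, the read-out therefore does not separate the two groups, although fluoro brings fewer heavy atoms and no hydrogen-bond acceptor. Compound 2 and compound 3 each give a limit of the assay rather than a number, and neither provides a step at this position: the limit of > 50000 nM in this assay, at which 2 of the 4 values shown sit.

On these data alone, whether other groups at this position, such as an amine, a carboxylic acid or a longer alkoxy chain, would also leave the read-out unmoved remains open. The compounds shown also leave open how much the read-out depends on the sulfonamide group.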